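This account rests on a few compounds, and the source may have more. Where it says the series, first, only, none or still open, it means among the compounds named here.

Measured so far in an assay on isolated protein for inhibition of leukotriene B4 receptor 1 (Homo sapiens), tested at 10 uM; a higher number here means more inhibition at the concentration tested (going by the name of the read-out), a lower number less inhibition:
compound 1 `CCCc1cc(C(C)=O)c(O)cc1OCCCCC#N` gives 84%
compound 2 `CCCCCCc1cc(C(C)=O)c(O)cc1OCCCCC#N` gives 51%

Going by the values given here, compound 2 holds the lower of the two numbers in this assay; its nearest neighbour is compound 1, and the only step between measured compounds, a number 33 percentage points lower from compound 1 to compound 2 (beyond the scatter), separates them. Compound 3 `CC(=O)c1cc(C(C)=O)c(OCCCCC#N)cc1O` has not yet been measured. It differs from compound 2 in one place: acetyl in place of hexyl on an aromatic carbon. Among the compounds with values here, no measured step replaces a hexyl with an acetyl, so the only step that bears on this change is the one from compound 1 to compound 2, in which the longer chain at the same position went with a number lower by an amount well beyond the scatter. Within the data shown here, the acetyl is shorter than the hexyl, but it also brings a hydrogen-bond acceptor that neither measured compound carries at this position, so the single step is a weak guide. The step is nonetheless expected to be a number 17 percentage points higher from compound 2 to compound 3 (beyond the scatter), upward, because a number 33 percentage points lower from compound 1 to compound 2 (beyond the scatter) pairs the shorter group with the higher number. Compound 3 is estimated at 68%, within a range from 40% to 90%.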

Compound 3, a percentage reported as inhibition, at one concentration (the size of the read-out at that concentration, not a potency): 8%
The estimate for compound 3 lay 60 percentage points above the measured number, outside the stated range (below it).
By their numbers in this assay, from the lowest: compound 3; then compound 2; then compound 1.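

In this assay, putting an acetyl on this aromatic carbon, ortho to a 4-cyanobutoxy group and para to a hydroxy group, gives a number 43 percentage points lower from compound 2 to compound 3 (beyond the scatter), and against the propyl it gives a number 76 percentage points lower from compound 1 to compound 3 (beyond the scatter). Going by these compounds alone, the earlier pair showed only that the propyl stood above the hexyl, whereas compound 3 shows that the number here does not simply rise as the group gets shorter: the acetyl, shorter than the hexyl, stands beneath both alkyl groups, and it is the only one of the three groups that carries a hydrogen-bond acceptor. Nothing available here accounts for this fall.

The three compounds cannot separate the presence of the carbonyl from the loss of an alkyl chain, as the acetyl differs from both alkyl groups in more than one respect. An ethyl or a methyl at this position would show how far the alkyl series itself runs, while a methoxy or a hydroxy would show whether other oxygen-bearing groups share the low number of compound 3.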